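The source may report more compounds than this note shows. Statements on the series, on what has been measured and on what is new or still open speak of the compounds shown alone.

Compound 1 `CCc1cccc2ccc(-c3ccc(C(/C=C4\OC(=O)NC4=O)(CC)CC)c(=O)[nH]3)cc12` and compound 2 `CCC(/C=C1\OC(=O)NC1=O)(CC)c1ccc(-c2ccc3cccc(F)c3c2)[nH]c1=O` share one core and differ in a single group. In an ADME assay on microsomes from liver (Rattus norvegicus) for metabolic stability (on this read-out lower numbers stand for a shorter-lived compound and higher numbers for a longer-lived compound), compound 1 gives 1.77 h. For compound 2 this assay reports only a limit, > 3 h, not a number. The step of an at least 1.6-fold higher number from compound 1 to compound 2 (0.22 log units; that floor lies within the scatter) therefore rests on that limit (the limit of > 3 h in this assay, at which 1 of the 2 values shown sits), and compound 2 sits at the limit of this assay, with no measured value beyond it. Compound 3 `CCC(/C=C1\OC(=O)NC1=O)(CC)c1ccc(-c2ccc3cc(F)cc(F)c3c2)[nH]c1=O` has not yet been measured; it differs from compound 2 by fluoro in place of hydrogen on an aromatic carbon. No measured step here covers fluoro in place of hydrogen, so the one step shown, which swaps ethyl for fluoro, bears on it only loosely. Within the data shown here, with no closely comparable step, no change beyond the scatter is expected, and compound 3 is estimated at 4 h, within 2 h to 8 h, an expected step that the limit leaves unreadable from compound 2 to compound 3.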

Compound 3, half-life: > 3 h
Compound 3: no number, only a limit; the forecaster's own chance of this, stated with the estimate: 60%; the middle value lies beyond the limit too.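

Compound 2 and compound 3 both reach only a limit in this assay, not a number, so no step between them can be read: the limit of > 3 h in this assay, at which 2 of the 3 values shown sit.

As far as these compounds go, how far each compound lies past that limit stays open, as does whether fluoro in place of hydrogen changes the half-life at all.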